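The source may hold more compounds than are shown below. What is called first, only, known or untested is meant among the compounds shown, and "the series" means these compounds.

Compound 1, `CC1=CC[C@H](C(C)(C)NC(=S)N/N=C/c2ccccc2)CC1`, in a functional assay on UACC-62 cells (Homo sapiens) for inhibition, read by sulforhodamine B assay, with a stated time of 48 h (a lower number here means a stronger inhibitor of growth, a higher number a weaker inhibitor of growth), gives > 100000 nM, which is a limit of the assay.
Compound 2, `CC1=CC[C@H](C(C)(C)NC(=S)N/N=C/c2cccc(Cl)c2)CC1`, in this assay gives 39800 nM.

Among the compounds with values here, compound 2 holds the only actual number recorded in this assay; the one other value shown is a limit rather than a number. Compound 3, `CC1=CC[C@H](C(C)(C)NC(=S)N/N=C/c2ccco2)CC1`, differs from compound 2 in one place: furan-2-yl in place of 3-chlorophenyl on a carbon with a double bond to nitrogen. A single measured step bears on this change, namely an at least 2.5-fold lower number from compound 1 to compound 2 (0.40 log units; beyond the scatter), in which the chloro entered the ring. Compound 3 carries no chloro at all, and a different ring besides, so the number for compound 3 is expected to move back upward because an at least 2.5-fold lower number from compound 1 to compound 2 (0.40 log units; beyond the scatter) was the whole gain tied to the chloro. A real chance remains that compound 3 is reported only at the limit of > 100000 nM in this assay, at which 1 of the 2 values shown sits. Compound 3 is therefore estimated at 100000 nM, within 35000 nM to 300000 nM, an expected step of a 2.5-fold higher number from compound 2 to compound 3 (0.40 log units; beyond the scatter).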

Compound 3, concentration for total growth inhibition: 14100 nM
Compound 3: middle estimate off by 7.1-fold (0.85 log units), on the high side; the measured number lies below the stated range.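

In this assay, a lower number on the carbon with a double bond to nitrogen does not depend on a chloro: furan-2-yl in place of 3-chlorophenyl gives a 2.8-fold lower number from compound 2 to compound 3 (0.45 log units; beyond the scatter), and furan-2-yl in place of phenyl gives an at least 7.0-fold lower number from compound 1 to compound 3 (0.85 log units; beyond the scatter). The furan-2-yl group, with its five-membered aromatic ring and one oxygen, thus gives a lower number than either six-membered carbon ring shown, so adding chloro to the phenyl ring is not the only change here that lowers the number. Compound 1 remains the only compound of the three reported at a limit: the limit of > 100000 nM in this assay, at which 1 of the 3 values shown sits.

As far as these compounds go, whether thiophen-2-yl or pyridin-2-yl would give a number as low as furan-2-yl remains open. So does whether a chloro on the furan-2-yl ring would lower the number further.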